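Dropping the Pentyl Chain of Compound 1

The compounds below may be only part of what the source reports. "The series", "measured", "known", "first", "only" and "open" are said of these compounds alone.

Measured so far:
compound 1, `CCCCC[C@H](CN(O)C=O)C(=O)NCNC(=O)c1cc2cccc(OC)c2o1`, 160 nM
compound 2, `CCCCC[C@@H](C(=O)NCNC(=O)c1cc2cccc(OC)c2o1)[C@@H](CC)N(O)C=O`, 126 nM

In an assay on CHO cells for inhibition of bone morphogenetic protein 1 (Homo sapiens), with stated times of 10 min and 60 min (a higher number here means a weaker inhibitor, a lower number a stronger inhibitor), compound 1 gives 160 nM, the highest of the two numbers shown. Compound 2 gives 126 nM, and the step of a 1.3-fold lower number from compound 1 to compound 2 (0.10 log units; within the scatter) lies within the scatter. Compound 3 `COc1cccc2cc(C(=O)NCNC(=O)CCN(O)C=O)oc12` differs from compound 1 in this way: hydrogen in place of pentyl on a saturated chain carbon bound to a carbonyl carbon and a saturated chain carbon. For the measured compounds named here, the single measured step, a 1.3-fold lower number from compound 1 to compound 2 (0.10 log units; within the scatter), adds a group at another carbon and does not test removal of the pentyl chain, so it bears on the new step only loosely. Compound 3 is expected to give 1500 nM, in the range 400 nM to 6000 nM. That estimate means an expected step of a 9.4-fold higher number from compound 1 to compound 3 (0.97 log units; beyond the scatter), beyond the scatter toward a weaker inhibitor.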

Compound 3, half-maximal inhibitory concentration: 6300 nM
Compound 3: middle estimate off by 4.2-fold (0.62 log units), on the low side, outside the stated range (above it).
By their numbers in this assay, from the lowest: compounds 2 and 1 (each within the scatter of the next); then compound 3.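

In this assay, hydrogen in place of pentyl gives a 39-fold higher number from compound 1 to compound 3 (1.60 log units; beyond the scatter), a large step beyond the scatter. For the compounds shown here, compounds 1 and 2 both carry the pentyl chain, so only this change shows that the number at this position depends strongly on whether that chain is present. Nothing shown here accounts for the size of the step.

As far as these compounds go, it remains open whether a propyl chain, a longer chain such as heptyl, or a chain ending in an amine or a carboxylic acid would keep the number near that of compound 1. Also open, from the compounds shown here alone, is what the ethyl group of compound 2 would do without the pentyl chain.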